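The compounds below may be only part of what the source reports. "The series", "measured", "known", "first", "only" and "open" are said of these compounds alone.

Compound 1 `CC(=O)N1CCC(C(=O)NCCCNc2nc(Nc3cccc(F)c3)ncc2Br)CC1` was tested in an assay on isolated protein for inhibition of serine/threonine-protein kinase TBK1 (Homo sapiens) (on this read-out lower numbers stand for stronger inhibition and higher numbers for weaker inhibition), where compound 1 gives 430 nM. Among the measured compounds shown here, of the two compounds measured so far, compound 1 carries the highest number, which here means the weakest inhibition. The other measured compound, compound 2 `CN1CCC(c2ccc(Nc3ncc(C4CC4)c(NCCCNC(=O)C4CCC4)n3)cc2)CC1`, gives 8 nM in this assay, a much lower number that lies well beyond the scatter; since the two compounds differ in several places at once, that gap cannot be tied to any single change. Compound 3 `O=C(NCCCNc1nc(Nc2cccc(F)c2)ncc1Br)C1CCC1` has not yet been tested. It differs from compound 1 in one place: cyclobutyl in place of 1-acetylpiperidin-4-yl on a carbonyl carbon. Compound 2 also carries a cyclobutyl on a carbonyl carbon, but its other differences from compound 1 prevent any step from being read off. Only a small step is expected, a 1.4-fold lower number from compound 1 to compound 3 (0.16 log units; within the scatter), most likely within the scatter. Compound 3 is therefore estimated at 300 nM, within a range from 100 nM to 900 nM.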

Compound 3, half-maximal inhibitory concentration: 2 nM
The estimate for compound 3 lay 150-fold (2.18 log units) above the measured number; the measured number lies below the stated range.
By their numbers in this assay, from the lowest: compound 3; then compound 2; then compound 1.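

Among the compounds shown here, at this position, on a carbonyl carbon whose other neighbour is an amide-type nitrogen, the choice of group matters far more than the earlier compounds could reveal: in this assay cyclobutyl in place of 1-acetylpiperidin-4-yl gives a 220-fold lower number from compound 1 to compound 3 (2.33 log units; beyond the scatter) on an otherwise unchanged molecule. The entering group is the smaller, with 4 heavy atoms against 9 and 0 hydrogen-bond acceptors against 1, so on this core the larger acetylated ring is not required for strong inhibition. No measurement at hand explains why the number falls so far.

With only these two groups compared here, ring size cannot be separated from the loss of the acetyl or the ring nitrogen. Cyclopropyl, cyclopentyl or an unsubstituted piperidin-4-yl on the same carbonyl carbon would help to tell these apart.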